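Flipping One Stereocentre at a Saturated Ring Carbon

A few compounds are considered here, and "the series" means these few. Any claim that something is new, unique, unknown or untested is made for them only; others in the source may bear on it.

Of the compounds shown here, three have so far been tested in an ADME assay on cells (kidney, Oryctolagus cuniculus) for cytotoxicity; a higher number here means that more compound is tolerated, a lower number that less compound is tolerated. Compound 1 `CC(=O)Nc1ccn(C2OC(CO[Si](C)(C)C(C)(C)C)C(C#N)C2O[Si](C)(C)C(C)(C)C)c(=O)n1` reaches only a limit there, > 4 ug/mL. Compound 2 `Cc1cn([C@H]2C[C@@H](C#N)[C@@H](CO)O2)c(=O)[nH]c1=O` likewise reaches only a limit in this assay, > 400 ug/mL. Compound 3 `Cc1cn(C2CC(C#N)C(CO[Si](C)(C)C(C)(C)C)O2)c(=O)[nH]c1=O` also returns a limit rather than a number, > 100 ug/mL. Because all three values are limits, compound 2 cannot be ranked against the others; what can be said is that its value is the limit of > 400 ug/mL in this assay, at which 1 of the 3 values shown sits.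

Compound 4 `Cc1cn([C@H]2C[C@H](C#N)[C@@H](CO)O2)c(=O)[nH]c1=O` has not yet been measured. It differs from compound 2 as follows: the two compounds have the same atoms and bonds and differ only in configuration as drawn: 1 of 3 stereo elements differ; a stereocentre at a saturated ring carbon is drawn S in compound 2 and R in compound 4. Among the measured compounds shown here, no step between measured compounds exists to lean on, so the expectation rests on the structural change alone. With the same atoms and bonds and only one stereocentre at a saturated ring carbon redrawn, no shift beyond the usual scatter is expected in this assay, and a further limit seems the most likely outcome. Compound 4 is therefore estimated at 400 ug/mL, with a range from 100 ug/mL to 1000 ug/mL. The expected step of a number no higher from compound 2 to compound 4 (the limit leaves the size open) is essentially none.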

Compound 4, minimum cytotoxic concentration: 100 ug/mL
Compound 4: middle estimate off by 4.0-fold (0.60 log units), on the high side; low and high end bracket the measured number.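

In this assay, redrawing this one stereocentre at a saturated ring carbon gives an at least 4.0-fold lower number from compound 2 to compound 4 (0.60 log units; beyond the scatter). Compound 4 is the only compound shown that reaches a number, 100 ug/mL, rather than a limit, so the earlier values could not show that configuration at this carbon can move the result in this assay beyond the scatter. With nothing entering or leaving, the step can be traced to configuration alone: the fact that compounds 2 and 4 differ only in the configuration as drawn

The compounds shown leave open how large the full step is, as the value of compound 2 is a limit, and whether the other two stereo elements matter in the same way. They also leave open whether this carbon would respond alike with a carboxylic acid or an amine in place of the nitrile.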